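A few compounds are considered here, and "the series" means these few. Any claim that something is new, unique, unknown or untested is made for them only; others in the source may bear on it.

Of the compounds shown here, three have so far been measured in a functional assay on cells for inhibition of Polyunsaturated fatty acid 5-lipoxygenase (Homo sapiens); a higher number here means a weaker inhibitor, a lower number a stronger inhibitor. Compound 1 `O=C1NCCN(c2cccc(OCc3ccccc3)c2)N1` gives 200 nM, compound 2 `CCC1CN(c2ccccc2)NC(=O)N1` gives 3800 nM, and compound 3 `O=C1NCCN(c2ccccn2)N1` gives 8600 nM. Compound 3 thus has the highest number of the three and is the weakest inhibitor among them: its gap to compound 2 lies beyond the usual scatter, and its gap to compound 1 is far wider still. Compound 4 `O=C1NCCN(c2cccc(Cl)n2)N1` differs from compound 3 in a single place: chloro in place of hydrogen on an aromatic carbon of a six-membered aromatic ring with 1 nitrogen, next to the ring nitrogen. For the measured compounds named here, no pair of measured compounds differs by exactly this change, so its size cannot be read from the data directly. The expectation is a modest gain in potency, a step of a 2.2-fold lower number from compound 3 to compound 4 (0.33 log units; beyond the scatter) in this assay rather than no change at all. Compound 4 is therefore estimated at 4000 nM, with a likely range from 1500 nM to 12000 nM.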

Compound 4, half-maximal inhibitory concentration: 4800 nM
The estimate for compound 4 lay 1.2-fold (0.08 log units) below the measured number; low and high end bracket the measured number.
By their numbers in this assay, from the lowest: compound 1; then compounds 2, 4 and 3 (each within the scatter of the next, the first and the last beyond it).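

In this assay, for the compounds shown here, putting chloro in place of hydrogen on an aromatic carbon, next to the ring nitrogen, gives a 1.8-fold lower number from compound 3 to compound 4 (0.25 log units; within the scatter) and so provides the first direct reading of this change at this position. The step is too small to separate from the differences seen between repeated measurements, so compound 3 and compound 4 cannot be ranked, and a single chlorine atom here has no clear effect on the number. No measurement at hand explains the size of this step.

From the compounds shown here alone, whether an amine, a methoxy group or a carboxylic acid on the same carbon would produce a step beyond the scatter remains open. It is also unknown whether chloro would give a similar step on another carbon of this ring.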